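A few compounds are considered here, and "the series" means these few. Any claim that something is new, unique, unknown or untested is made for them only; others in the source may bear on it.

Of the compounds shown here, two built on a shared core have been tested in a functional assay on MDA-MB-435S cells (Homo sapiens) for cytotoxicity, read by MTT assay, with a stated time of 72 h; a higher number here means a weaker inhibitor, a lower number a stronger inhibitor. Compound 1 `Cc1nnc(SCc2cc(=O)c3ccccc3o2)o1` reaches only a limit of the assay there, giving > 25000 nM. Compound 2 `Cc1nnc(SCc2cc(=O)c3cc(Cl)ccc3o2)s1` likewise reaches only a limit in this assay, with > 25000 nM. Compound 2 thus stands at the limit, where every value shown so far sits (the limit of > 25000 nM in this assay, at which 2 of the 2 values shown sit). Compound 3 `Cc1ccc2oc(CSc3nnc(C)s3)cc(=O)c2c1` differs from compound 2 by methyl in place of chloro on an aromatic carbon. Among the compounds with values here, no step between two measured compounds is available, so the change of methyl in place of chloro on an aromatic carbon gives no direction to lean on; in this assay any step is expected to stay within the scatter, with neither a gain nor a loss clearly beyond it. Compound 3 is therefore expected to give about 30000 nM, between 10000 nM and 100000 nM, most likely again as a limit, which means an expected step that the limit leaves unreadable from compound 2 to compound 3.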

Compound 3, half-maximal inhibitory concentration: > 25000 nM
Compound 3: no number, only a limit (the forecaster's own chance of this, stated with the estimate: 80%); the middle value does not contradict the limit.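

Compound 2 and compound 3 both stand at a limit of the assay, so the step of methyl in place of chloro on an aromatic carbon cannot be read. The compounds shown leave open whether any change to the shared core gives a measurable value in this assay.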